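Diethylamide in Place of a Methylpiperidine Amide

A few compounds are considered here, and "the series" means these few. Any claim that something is new, unique, unknown or untested is made for them only; others in the source may bear on it.

Compound 1 `COc1cc(-n2cccc2C(=O)O)ccc1Nc1ncc(Cl)c(Nc2ccccc2NS(C)(=O)=O)n1` gives 1060 nM in a functional assay on A549 cells (Homo sapiens) for antiproliferative activity, read by MTT assay, with a stated time of 72 h; on this read-out higher numbers stand for weaker inhibition and lower numbers for stronger inhibition. Compound 2 `COc1cc(-n2cccc2C(=O)N2CCCCC2)ccc1Nc1ncc(Cl)c(Nc2ccccc2NS(C)(=O)=O)n1` reaches only the limit of this assay, > 10000 nM. Compound 3 `COc1cc(-n2cccc2C(=O)N2CCC(C)CC2)ccc1Nc1ncc(Cl)c(Nc2ccccc2NS(C)(=O)=O)n1` gives 2200 nM in this assay.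

Compound 3 stands highest of the two numbers, with compound 1 nearest: a 2.1-fold higher number from compound 1 to compound 3 (0.32 log units; beyond the scatter). The value of compound 2 sits at the limit of > 10000 nM in this assay, at which 1 of the 3 values shown sits. Compound 4 `CCN(CC)C(=O)c1cccn1-c1ccc(Nc2ncc(Cl)c(Nc3ccccc3NS(C)(=O)=O)n2)c(OC)c1` differs from compound 3 by diethylamino in place of 4-methylpiperidin-1-yl on a carbonyl carbon. Going by the values given here, the steps that bear on the amine part are an at least 9.4-fold higher number from compound 1 to compound 2 (0.97 log units; beyond the scatter) and an at least 4.5-fold lower number from compound 2 to compound 3 (0.65 log units; beyond the scatter), so the amine attached to the carbonyl shifts this assay strongly, and a ring-free amine has not been tested. A modest rise is expected for compound 4, a 1.8-fold higher number from compound 3 to compound 4 (0.26 log units; within the scatter). Compound 4 is estimated at 4000 nM, between 1500 nM and 12000 nM.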

Compound 4, half-maximal inhibitory concentration: 970 nM
Estimate against measurement, compound 4: 4.1-fold (0.62 log units) above, outside the stated range (below it).
By their numbers in this assay, from the lowest: compounds 4 and 1 (each within the scatter of the next); then compound 3. At a limit, above all of these: compound 2.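

In this assay the open-chain diethylamino group on the carbonyl carbon gives lower numbers than both ring amines, with a 2.3-fold lower number from compound 3 to compound 4 (0.36 log units; beyond the scatter) and an at least 10-fold lower number from compound 2 to compound 4 (1.01 log units; beyond the scatter), so an amide at this place needs no ring to reach this level. The second step starts from a limit, not a number: the limit of > 10000 nM in this assay, at which 1 of the 4 values shown sits. The carboxylic acid and the diethylamide stand level, with a 1.1-fold lower number from compound 1 to compound 4 (0.04 log units; within the scatter).

On these data alone, whether dimethylamino, dipropylamino or a morpholine amide would hold this level remains open.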